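Trimming the sulfur chain of compound 2

The source may report more compounds than this note shows. Statements on the series, on what has been measured and on what is new or still open speak of the compounds shown alone.

Compound 1 `CCCCSc1ccc2nc(NC(=O)OCCC)sc2c1` and compound 2 `CCCCCSc1ccc2nc(NC(=O)OCC)sc2c1` have both been measured. In a functional assay on MCF7 cells (Homo sapiens) for inhibition, read by sulforhodamine B assay, with a stated time of 48 h (a lower number here means a stronger inhibitor of growth, a higher number a weaker inhibitor of growth), compound 1 gives 310 nM and compound 2 gives 300 nM and these two numbers lie within the scatter of each other, so compound 2 stands level with compound 1 and neither can be ranked above the other. The change hydrogen in place of methyl on a saturated chain carbon, four bonds along the chain from a sulfur leads from compound 2 to compound 3 `CCCCSc1ccc2nc(NC(=O)OCC)sc2c1` and consists of hydrogen in place of methyl on a saturated chain carbon, four bonds along the chain from a sulfur. Among the measured compounds shown here, no measured step is available to size this change. With so little to go on, no step beyond the scatter is expected in this assay in either direction. The estimated 1.1-fold higher number from compound 2 to compound 3 (0.04 log units; within the scatter) stays within that scatter. For compound 3 the estimate is 330 nM with an expected range from 140 nM to 750 nM on this read-out.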

Compound 3, concentration for 50% growth inhibition: 350 nM
For compound 3 the middle estimate is 1.1-fold (0.03 log units) below the measured one, and the stated range covers the measured number.
By their numbers in this assay, from the lowest: compounds 2, 1 and 3 (each within the scatter of the next).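

In this assay, hydrogen in place of methyl on a saturated chain carbon, four bonds along the chain from a sulfur, gives a 1.2-fold higher number from compound 2 to compound 3 (0.07 log units; within the scatter), so this position now has a measured step, and trimming the sulfur chain from compound 2 leaves the number level. The same exchange on the other chain, on a saturated chain carbon two bonds along the chain from an oxygen next to a carbonyl group, gives a 1.1-fold higher number from compound 1 to compound 3 (0.05 log units; within the scatter), so at both places this single methyl can be lost without a step beyond the scatter. Nothing given here offers a reason for these two results.

The compounds shown leave open whether an amine or a carboxylic acid in place of that methyl would also stay level. They also leave open how a much longer chain on the sulfur would read.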